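Chain extension in a cytotoxicity series: working notes

The source may hold more compounds than are shown below. What is called first, only, known or untested is meant among the compounds shown, and "the series" means these compounds.

Compound 1 `CC1=C(SCCC(=O)OC(C[Se]c2ccccc2)C(=O)NCCCCCC(=O)OCc2ccccc2)C(=O)c2ccccc2C1=O` and compound 2 `CC1=C(SCCC(=O)OC(CC[Se]c2ccccc2)C(=O)NCCCCCC(=O)OCc2ccccc2)C(=O)c2ccccc2C1=O` share one core; compound 3 `CC1=C(SCCC(=O)OC(C[Se]c2ccccc2)C(=O)NC(C)(C)C)C(=O)c2ccccc2C1=O` and compound 4 `CC1=C(SCCC(=O)OC(CC[Se]c2ccccc2)C(=O)NC(C)(C)C)C(=O)c2ccccc2C1=O` share another. The difference between the two cores is not broken down here. In an ADME assay on HUVEC cells (Homo sapiens) for cytotoxicity, read by MTT assay, with a stated time of 24 h (a higher number here means a weaker inhibitor, a lower number a stronger inhibitor), compound 1 gives 23000 nM, and compound 2 gives 17000 nM. Between them lies (a group of 8 heavy atoms (7 carbon, 1 selenium; one six-membered aromatic ring of carbon only) in place of a group of 7 heavy atoms (6 carbon, 1 selenium; one six-membered aromatic ring of carbon only), on a saturated chain carbon, two bonds along the chain from a carbonyl carbon and an oxygen next to a carbonyl group), and that single change made a 1.4-fold lower number from compound 1 to compound 2 (0.13 log units; within the scatter). Compound 3 gives 34000 nM in this assay, which puts it alongside compound 1 and compound 2 within the scatter. Compound 4 carries the same change on its own core: a group of 8 heavy atoms (7 carbon, 1 selenium; one six-membered aromatic ring of carbon only) in place of a group of 7 heavy atoms (6 carbon, 1 selenium; one six-membered aromatic ring of carbon only), on a saturated chain carbon, two bonds along the chain from a carbonyl carbon and an oxygen next to a carbonyl group. Among the compounds with values here, from compound 3 to compound 4 the step expected in this assay is a 1.3-fold lower number from compound 3 to compound 4 (0.10 log units; within the scatter), set beside the earlier one, and it rests on the one measured instance of this change, which gave a 1.4-fold lower number from compound 1 to compound 2 (0.13 log units; within the scatter) within the scatter. Compound 4 is therefore estimated at 27000 nM in this assay, with an expected range from 14000 nM to 52000 nM. Within the data shown here, a wider range is kept than the single earlier step suggests, since only one instance of the change has been measured.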

Compound 4, half-maximal inhibitory concentration: 13000 nM
Beside the measured number, compound 4's estimate is 2.1-fold (0.32 log units) above it, outside the stated range (below it).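

In this assay, the group of 8 heavy atoms in place of the group of 7 heavy atoms, on the same saturated chain carbon, gives a 2.6-fold lower number from compound 3 to compound 4 (0.42 log units; beyond the scatter). Set beside the earlier step on the other core, this step cannot be told apart from it in size: the same change on two cores in this assay, a 1.4-fold lower number (0.13 log units; within the scatter) from compound 1 to compound 2 and a 2.6-fold lower number (0.42 log units; beyond the scatter) from compound 3 to compound 4, 1.9-fold (0.29 log units) apart, within the scatter of two such steps. Within the data shown here, the change can therefore be carried between these two cores with no measured difference in its step, although only the step on the core of compound 3 lies beyond the scatter, and two cores show neither that the step holds on a further core nor why it arises.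

The compounds shown leave open whether a longer chain at this saturated chain carbon would extend the step or leave the number in place. They also leave open whether the step would persist with an amine or a carboxylic acid at the end of the amide chain on the core of compound 1.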